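Hydrazone aryl variation in a 4-hydroxybenzofuran series

This account rests on a few compounds, and the source may have more. Where it says the series, first, only, none or still open, it means among the compounds named here.

Measured compounds:
compound 1 `Cc1c(C(=O)N/N=C\c2cccc(F)c2O)oc2cccc(O)c12`, 12700 nM
compound 2 `Cc1c(C(=O)N/N=C\c2cc(O)ccc2O)oc2cccc(O)c12`, 95500 nM
compound 3 `Cc1c(C(=O)N/N=C\c2cccnc2)oc2cccc(O)c12`, a limit, >= 40000 nM

In a functional assay on PC-3 cells (Homo sapiens) for inhibition (a higher number here means a weaker inhibitor, a lower number a stronger inhibitor), compound 2 gives 95500 nM, the highest of the two readable numbers; compound 1 gives 12700 nM. For compound 3 this assay returns only a limit, >= 40000 nM (the limit of >= 40000 nM in this assay, at which 1 of the 3 values shown sits).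

Compound 4 `Cc1c(C(=O)N/N=C\c2ccc(F)cc2)oc2cccc(O)c12` differs from compound 2 as follows: 4-fluorophenyl in place of 2,5-dihydroxyphenyl on a carbon with a double bond to nitrogen. The measured steps that touch the carbon with a double bond to nitrogen are a 7.5-fold higher number from compound 1 to compound 2 (0.88 log units; beyond the scatter) and an at least 3.1-fold higher number from compound 1 to compound 3 (0.49 log units; beyond the scatter); the step that the limit leaves unreadable from compound 2 to compound 3 is unreadable. Both readable steps show that the aryl group at this position shifts the number modestly, and that losing the hydroxyl pattern of compound 1 weakens inhibition. Compound 4 carries no hydroxyl at all, like compound 3, so a number near the limit seen for compound 3 is expected, somewhat below compound 2.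

Compound 4 is therefore estimated at 40000 nM, ranging from 10000 nM to 150000 nM, which is expected to correspond to a 2.4-fold lower number from compound 2 to compound 4 (0.38 log units; beyond the scatter).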

Compound 4, half-maximal inhibitory concentration: >= 40000 nM
Compound 4: only a limit was reported; the forecaster's own chance of this, stated with the estimate: 40%; the middle value lies on the limit itself.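

In this assay compound 4 returns only a limit, >= 40000 nM. Fluorine on the aryl ring is therefore not enough to keep the number of compound 1: 4-fluorophenyl in place of 3-fluoro-2-hydroxyphenyl gives an at least 3.1-fold higher number from compound 1 to compound 4 (0.49 log units; beyond the scatter), and this is the first readable step in which the aryl group carries fluorine but no hydroxyl. The steps from compound 2 to compound 4 and from compound 3 to compound 4 cannot be read, and two compounds now sit at the same limit: the limit of >= 40000 nM in this assay, at which 2 of the 4 values shown sit.

On these data alone, without a readable number for compound 3 or compound 4, their order relative to compound 2 stays open. Also open, as far as these compounds go, is how a plain 2-hydroxyphenyl or a 2-aminophenyl would read on this carbon, which would help separate the contributions of the hydroxyl and the fluorine in compound 1.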